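Pyrazole substitution in the isopropoxy-benzamide series

This account rests on a few compounds, and the source may have more. Where it says the series, first, only, none or still open, it means among the compounds named here.

For the measured compounds named here, compound 3 `Cc1c(-c2cncc(-c3ccc(C(N)=O)c(OC(C)C)c3)c2)cnn1C` gives 2200 nM in an assay on HeLa cells for inhibition of MAP kinase-interacting serine/threonine-protein kinase 1/2 (Homo sapiens), read by AlphaScreen, with a stated time of 2 h (a lower number here means a stronger inhibitor, a higher number a weaker inhibitor), the highest of the three numbers measured so far; its nearest neighbour is compound 2 `Cc1[nH]ncc1-c1cncc(-c2ccc(C(N)=O)c(OC(C)C)c2)c1` at 320 nM and the furthest is compound 1 `CC(C)Oc1cc(-c2cncc(-c3cnn(C4COC4)c3)c2)ccc1C(N)=O` at 200 nM, both steps beyond the scatter. Compound 4 `CC(C)Oc1cc(-c2cncc(-c3cnn(C)c3)c2)ccc1C(N)=O` differs from compound 3 by hydrogen in place of methyl on an aromatic carbon. Going by the values given here, no measured pair tests exactly this removal of a carbon-bound methyl. The step that comes closest is a 6.9-fold higher number from compound 2 to compound 3 (0.84 log units; beyond the scatter), which shows that adding a methyl on the ring nitrogen while the carbon methyl is present costs potency; the steps of a 1.6-fold higher number from compound 1 to compound 2 (0.20 log units; within the scatter) and an 11-fold higher number from compound 1 to compound 3 (1.04 log units; beyond the scatter) show that a pyrazole carrying only a nitrogen substituent, or a hydrogen with the carbon methyl, sits near compound 1. Compound 4 keeps the nitrogen methyl but loses the carbon methyl, so part of the loss seen in compound 3 is expected to be recovered, giving an expected step of a 3.7-fold lower number from compound 3 to compound 4 (0.56 log units; beyond the scatter) in this assay. The estimate for compound 4 is 600 nM, expected to fall between 200 nM and 2000 nM.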

Compound 4, half-maximal inhibitory concentration: 750 nM
The estimate for compound 4 lay 1.3-fold (0.10 log units) below the measured number; measured number inside the range.
By their numbers in this assay, from the lowest: compounds 1 and 2 (each within the scatter of the next); then compound 4; then compound 3.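

In this assay, for the compounds shown here, taking the methyl off the aromatic carbon gives a 2.9-fold lower number from compound 3 to compound 4 (0.47 log units; beyond the scatter), the first direct reading of this position: with a methyl on the ring nitrogen, the carbon methyl carries a cost. The nitrogen substituent also matters when that carbon bears hydrogen, since methyl in place of oxetan-3-yl gives a 3.8-fold higher number from compound 1 to compound 4 (0.57 log units; beyond the scatter) and does not match compound 1. Moving the single methyl from the ring carbon to the ring nitrogen gives a 2.3-fold higher number from compound 2 to compound 4 (0.37 log units; beyond the scatter), so the two placements are not equivalent here.

Open, from the compounds shown here alone, is whether a methyl at this carbon has any effect with hydrogen on the ring nitrogen, and how a nitrogen substituent such as a 2-hydroxyethyl chain or an aminoethyl chain would compare with oxetan-3-yl. No evidence at hand explains these steps.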